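Methoxy Added to a Chalcone-Pyrazole Series

This account rests on a few compounds, and the source may have more. Where it says the series, first, only, none or still open, it means among the compounds named here.

Measured compounds:
compound 1, `COc1ccc(-c2cc(/C=C/C(=O)c3ccc(N)cc3)[nH]n2)cc1`, -40%
compound 2, `COc1ccc(C(=O)/C=C/c2cc(-c3cc(OC)c(OC)c(OC)c3)n[nH]2)cc1OC`, -64%
compound 3, `COc1ccc(-c2cc(/C=C/C(=O)c3ccc(N)cc3)[nH]n2)cc1OC`, -49%

In a functional assay on NCI-H460 cells (Homo sapiens) for cytotoxicity, read by sulforhodamine B assay, with a stated time of 48 h, tested at 10 uM (a higher number here means a weaker effect of the compound at the concentration tested, a lower number a stronger effect), compound 1 gives -40% and compound 3 gives -49%. The difference between them is methoxy in place of hydrogen on an aromatic carbon, and the step of a number 9 percentage points lower from compound 1 to compound 3 (within the scatter). Compound 2 gives -64% in this assay; the difference between its core and that of compound 1 is not broken down here.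

Compound 4, `COc1cc(C(=O)/C=C/c2cc(-c3cc(OC)c(OC)c(OC)c3)n[nH]2)cc(OC)c1OC`, has not yet been measured. It differs from compound 2 by methoxy in place of hydrogen on an aromatic carbon. This is the same kind of change as from compound 1 to compound 3, though the place is not identical: here the new group is also meta to a methoxy group. Because the earlier step of a number 9 percentage points lower from compound 1 to compound 3 (within the scatter) stayed within the scatter, a step of similar size is expected here, a number 6 percentage points lower from compound 2 to compound 4 (within the scatter). Compound 4 is therefore estimated at -70%, between -88% and -52%.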

Compound 4, a percentage reported as activity, at one concentration (the size of the read-out at that concentration, not a potency): -51%
Compound 4: middle estimate off by 19 percentage points, on the low side; the whole stated range lies below it.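

In this assay, methoxy in place of hydrogen on an aromatic carbon gives a number 13 percentage points higher from compound 2 to compound 4 (beyond the scatter), which means a weaker effect at the tested concentration once the new group is present. Set beside the earlier pair, the same change does not carry over from one core to the other with the same result: the same change on two cores in this assay, a number 9 percentage points lower (within the scatter) from compound 1 to compound 3 and a number 13 percentage points higher (beyond the scatter) from compound 2 to compound 4, 22 percentage points apart, beyond the scatter of two such steps

A step seen on the core of compound 1 therefore cannot simply be transferred to the core of compound 2, but two pairs do not show why they differ, and they cannot separate the effect of the core from that of the new group's place on the ring, which is not identical in the two pairs.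

The compounds shown leave open how this change behaves on any further core. They also leave open whether a hydroxyl or an ethoxy group on that same aromatic carbon would give a step like the one seen with methoxy.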